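From 3-fluorobenzyl to benzyl on a shared core

The source may hold more compounds than are shown below. What is called first, only, known or untested is meant among the compounds shown, and "the series" means these compounds.

In a functional assay on aorta (Rattus norvegicus, strain Sprague-Dawley) (a lower number here means that less compound is needed, a higher number that more compound is needed for the effect), compound 3 (`Cc1nn(-c2ccccc2)c2nc(OCc3cccc(F)c3)c(-c3nc(N)cc(N)n3)cc12`) gives 360 nM and holds the lower of the two numbers available. Compound 2 (`Cc1nn(-c2ccccc2)c2nc(OCc3ccccc3F)c(-c3nc(N)c(N(C)C)c(N)n3)cc12`) gives 1100 nM and lies higher by more than the usual scatter. Compound 1 (`Cc1nn(-c2ccccc2)c2nc(O)c(-c3nc(N)cc(N)n3)cc12`) stands at "not determined" (no result reported) and offers no comparison. Compound 4 (`Cc1nn(-c2ccccc2)c2nc(OCc3ccccc3)c(-c3nc(N)cc(N)n3)cc12`) has yet to be measured. It carries benzyl where compound 3 carries 3-fluorobenzyl (hydrogen in place of fluoro on an aromatic carbon), with hydrogen in place of fluoro on an aromatic carbon. For the measured compounds named here, no measured pair shows this change on its own. The expected change is a 1.1-fold higher number from compound 3 to compound 4 (0.05 log units; within the scatter) and thus none beyond the scatter. Compound 4 is estimated at 400 nM with a range from 130 nM to 1200 nM expected.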

Compound 4, half-maximal effective concentration: 10800 nM
The estimate for compound 4 lay 27-fold (1.43 log units) below the measured number, outside the stated range (above it).
By their numbers in this assay, from the lowest: compound 3; then compound 2; then compound 4.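

In this assay, hydrogen in place of fluoro on this aromatic carbon gives a 30-fold higher number from compound 3 to compound 4 (1.48 log units; beyond the scatter) and so is far from a neutral exchange on the shared core. For the compounds shown here, this is the first change in a single place that can be read, and it shows that one fluorine atom on the 3-fluorobenzyl group separates two clearly different numbers. From the compounds shown here alone, whether chloro, methoxy or an amine on the same aromatic carbon would keep the number close to that of compound 3 stays open. No measurement at hand gives a cause for this step.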